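Chloro substitution across two cores of one series

A few compounds are considered here, and "the series" means these few. Any claim that something is new, unique, unknown or untested is made for them only; others in the source may bear on it.

Measured so far in a functional assay on DLD-1 cells (Homo sapiens) for antiproliferative activity, read by CellTiter-Glo, with a stated time of 72 h; a lower number here means a stronger inhibitor, a higher number a weaker inhibitor:
Compound 1 `CC1CCN(C2CCN(S(=O)(=O)c3ccc(-c4ccccc4)cc3)CC2)CC1` gives 258 nM.
Compound 2 `CC1CCN(C2CCN(S(=O)(=O)c3ccc(-c4ccc(Cl)cc4)cc3)CC2)CC1` gives 105 nM.
Compound 3 `CC1CCN(C2CCN(S(=O)(=O)c3ccccc3-c3ccccc3)CC2)CC1` gives 0.96 nM.

Compound 1 and compound 2 differ by chloro in place of hydrogen on an aromatic carbon; this step is a 2.5-fold lower number from compound 1 to compound 2 (0.39 log units; beyond the scatter). Compound 3 has the same atoms as compound 1, joined differently; the difference between the two cores is not broken down here. Compound 3 stands lowest of the three, beyond the scatter against both compound 1 and compound 2, and is the most potent so far. Compound 4 `CC1CCN(C2CCN(S(=O)(=O)c3ccccc3-c3ccc(Cl)cc3)CC2)CC1` is not yet measured. It differs from compound 3 by chloro in place of hydrogen on an aromatic carbon, the same change in the same place as the one made on the core of compound 1. A step of similar size and direction, a 1.9-fold lower number from compound 3 to compound 4 (0.28 log units; within the scatter), is expected because the same change earlier gave a 2.5-fold lower number from compound 1 to compound 2 (0.39 log units; beyond the scatter). Compound 4 is estimated at 0.5 nM in this assay, expected between 0.15 nM and 2.5 nM.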

Compound 4, half-maximal inhibitory concentration: 202 nM
Beside the measured number, compound 4's estimate is 400-fold (2.61 log units) below it; measured number above the stated range.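

In this assay the chloro change does not carry from one core to the other: the same change on two cores in this assay, a 2.5-fold lower number (0.39 log units; beyond the scatter) from compound 1 to compound 2 and a 210-fold higher number (2.32 log units; beyond the scatter) from compound 3 to compound 4, 520-fold (2.71 log units) apart, beyond the scatter of two such steps. The new step is a 210-fold higher number from compound 3 to compound 4 (2.32 log units; beyond the scatter), against a 2.5-fold lower number from compound 1 to compound 2 (0.39 log units; beyond the scatter), so the two run in opposite directions and the result of phenyl to 4-chlorophenyl depends on the core that carries it. These two pairs show that a step read on one core cannot be used to estimate the same change on the other, but they do not show why the steps differ or how any further core in the series would respond.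

Still open, from the compounds shown here alone, is whether fluoro, methyl or methoxy in the same place would follow chloro on either core. Also open, going by these compounds, is how an amine or a carboxylic acid there would compare with hydrogen on the core of compound 3.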